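The source may hold more compounds than are shown below. What is called first, only, known or untested is meant among the compounds shown, and "the series" means these compounds.

In an ADME assay on BaF3 cells (Mus musculus) for antiproliferative activity, read by CCK-8 assay, with a stated time of 72 h (a higher number here means a weaker inhibitor of growth, a lower number a stronger inhibitor of growth), compound 1 `CN1CCN(Cc2ccc(NC(=O)CCSc3ccc4c(/C=C/c5ccccn5)n[nH]c4c3)cc2C(F)(F)F)CC1` gives 2480 nM, compound 2 `CN(C)CCN(C)Cc1ccc(NC(=O)CCSc2ccc3c(/C=C/c4ccccn4)n[nH]c3c2)cc1C(F)(F)F` gives 1850 nM and compound 3 `CC1CCN(Cc2ccc(NC(=O)CCSc3ccc4c(/C=C/c5ccccn5)n[nH]c4c3)cc2C(F)(F)F)CC1` gives 4170 nM. These three compounds differ only in the group on a saturated chain carbon bound to an aromatic carbon. Compound 3 cannot be told apart from compound 1, as shown by a 1.7-fold higher number from compound 1 to compound 3 (0.23 log units; within the scatter). Its gap to compound 2 is modest, as shown by a 2.3-fold higher number from compound 2 to compound 3 (0.35 log units; beyond the scatter).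

Compound 4 `O=C(CCSc1ccc2c(/C=C/c3ccccn3)n[nH]c2c1)Nc1ccc(CN2CCCC2)c(C(F)(F)F)c1` makes one further change at that place: pyrrolidin-1-yl in place of 4-methylpiperidin-1-yl on a saturated chain carbon bound to an aromatic carbon. In other words, (4-methylpiperidin-1-yl)methyl becomes (pyrrolidin-1-yl)methyl. Within the data shown here, no measured step makes this exact swap, so the closest guide is the set of swaps at the same place. Besides the two steps above, these include a 1.3-fold lower number from compound 1 to compound 2 (0.13 log units; within the scatter). All three are small, and only one goes just beyond the scatter. No step beyond the scatter is therefore expected in this assay.

The expected step is a 1.4-fold lower number from compound 3 to compound 4 (0.14 log units; within the scatter). The estimated value for compound 4 is 3000 nM, with an expected range from 1400 nM to 6300 nM.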

Compound 4, concentration for 50% growth inhibition: 4000 nM
Estimate against measurement, compound 4: 1.3-fold (0.12 log units) below; low and high end bracket the measured number.
By their numbers in this assay, from the lowest: compounds 2, 1, 4 and 3 (each within the scatter of the next, the first and the last beyond it).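

In this assay, replacing 4-methylpiperidin-1-yl, with 7 heavy atoms, by the smaller ring of pyrrolidin-1-yl, with 5, gives no readable change (a 1.0-fold lower number from compound 3 to compound 4 (0.02 log units; within the scatter)), so ring size and the methyl group make no visible difference in this pair. Pyrrolidin-1-yl also cannot be told apart from 4-methylpiperazin-1-yl (a 1.6-fold higher number from compound 1 to compound 4 (0.21 log units; within the scatter)), but it stands modestly apart from the open-chain amine (a 2.2-fold higher number from compound 2 to compound 4 (0.33 log units; beyond the scatter)), so compound 2 now lies beyond the scatter from both compound 3 and compound 4, while compound 1 lies within it of all three. No measurement available here explains these small differences.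

On these data alone, whether morpholin-4-yl or a diethylamino group would stay within this narrow band remains open. So does whether a longer amine chain than that of compound 2 would lower the number further.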